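Swapping a Hydroxymethyl Arm for a Methyl Group

The source may hold more compounds than are shown below. What is called first, only, known or untested is meant among the compounds shown, and "the series" means these compounds.

Measured compounds:
compound 1, `CCOc1ccccc1-c1ccc(-c2nc3cnccc3c(NC(C(N)=O)C3CC3)c2C#N)cc1`: 3
compound 2, `CC[C@@H](Nc1c(C#N)c(-c2ccc(-c3cccc(CO)c3)cc2)nc2cnccc12)C(N)=O`: 2

In a physicochemical assay for lipophilicity, read by HPLC, at pH 7.5 (a lower number here means a more polar compound, a higher number a more lipophilic compound), compound 1 gives 3 and compound 2 gives 2. Compound 2 is the more polar of the two, sitting below compound 1 by a margin beyond the scatter. Compound 3, `CC[C@@H](Nc1c(C#N)c(-c2ccc(-c3ccccc3C)cc2)nc2cnccc12)C(N)=O`, is not yet measured. It differs from compound 2 in one place: 2-methylphenyl in place of 3-(hydroxymethyl)phenyl on an aromatic carbon. Going by the values given here, no step between the measured compounds calibrates this change, so the expectation rests on the change itself. In this assay compound 3 is expected to be more lipophilic than compound 2, a step beyond the scatter: a number 1.30 log units higher from compound 2 to compound 3 (beyond the scatter). For compound 3 the estimate is 3.3, within 2.8 to 3.8.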

Compound 3, distribution coefficient: 3
Estimate against measurement, compound 3: 0.30 log units above, within the range that was stated.
By their numbers in this assay, from the lowest: compound 2; then compounds 1 and 3 (each within the scatter of the next).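

Going by these compounds alone, the exchange of 3-(hydroxymethyl)phenyl for 2-methylphenyl gives the first reading of a single-place change at this position in this assay, with a number 1.00 log units higher from compound 2 to compound 3 (beyond the scatter) as its step. This one step joins two differences, the loss of the hydroxyl and the different place of the substituent on the ring, and cannot divide the step between them. Nothing at hand explains the step.

Open, from the compounds shown here alone, is how 3-methylphenyl or 2-(hydroxymethyl)phenyl would read, which would separate those two differences. Also open, going by these compounds, is how a ring bearing an aminomethyl group or a carboxylic acid would read in this assay.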